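Group change on the sulfonyl sulfur

The source may hold more compounds than are shown below. What is called first, only, known or untested is meant among the compounds shown, and "the series" means these compounds.

In an ADME assay on CHO cells (Cricetulus griseus) for cytotoxicity, read by MTT assay (on this read-out higher numbers stand for weaker inhibition and lower numbers for stronger inhibition), compound 1 `O=S(=O)(NCC1COC1)c1cccc(-c2ccc3nccc(-c4ccncc4)c3n2)c1` gives 16000 nM and compound 2 `O=S(=O)(c1cccc(-c2ccc3nccc(-c4ccncc4)c3n2)c1)N1CCC(O)CC1` gives 8000 nM, two values within the scatter of each other. Compound 3 `C[C@@H]1CN(S(=O)(=O)c2cccc(-c3ccc4nccc(-c5ccncc5)c4n3)c2)C[C@H](C)N1` is not yet measured. It differs from compound 2 as follows: 3,5-dimethylpiperazin-1-yl in place of 4-hydroxypiperidin-1-yl on a sulfonyl sulfur. Among the compounds with values here, one measured step bears on this change, also made on a sulfonyl sulfur: a 2.0-fold lower number from compound 1 to compound 2 (0.30 log units; within the scatter). On this single step, no change beyond the scatter is expected in this assay, and no direction is firmly indicated. The estimated 1.3-fold lower number from compound 2 to compound 3 (0.12 log units; within the scatter) stays within the scatter. The estimate for compound 3 is 6000 nM, with an expected range of 2000 nM to 18000 nM.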

Compound 3, half-maximal inhibitory concentration: 6000 nM
Estimate against measurement, compound 3: no gap at the digits printed, within the range that was stated.
By their numbers in this assay, from the lowest: compounds 3, 2 and 1 (each within the scatter of the next, the first and the last beyond it).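

In this assay the step (a 1.3-fold lower number from compound 2 to compound 3 (0.12 log units; within the scatter)) keeps 3,5-dimethylpiperazin-1-yl level with 4-hydroxypiperidin-1-yl on the sulfonyl sulfur. Within the data shown here, the step (a 2.7-fold lower number from compound 1 to compound 3 (0.43 log units; beyond the scatter)) is the first at this position to lie beyond the scatter, though it is modest and spans only the two ends of the series, with compound 2 within the scatter of both. Nothing available accounts for either step.

Still open, from the compounds shown here alone, is how plain piperazin-1-yl, without the two methyl groups, would read in this assay. Going by these compounds, a carboxylic acid on the ring is equally open.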